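The compounds below may be only part of what the source reports. "The series", "measured", "known", "first", "only" and "open" are said of these compounds alone.

Measured so far in a functional assay on MCF7 cells (Homo sapiens) for antiproliferative activity, read by sulforhodamine B assay, with a stated time of 3 days; a lower number here means that less compound is needed, a higher number that more compound is needed for the effect:
- compound 1 `CCCC1=C(OCC)C(CCC)(CCC)C(=O)/C(=C(O)\C=C\c2ccccc2)C1=O`: 2.6 uM
- compound 2 `CCCCC1=C(OC)C(CCCC)(CCCC)C(=O)/C(=C(O)\C=C\c2ccccc2)C1=O`: 4.4 uM
- compound 3 `CCCC1=C(OC)C(CCC)(CCC)C(=O)/C(=C(O)\C=C\c2ccc(Br)cc2)C1=O`: "not determined" (no result reported)

Among the measured compounds shown here, compound 1 and compound 2 are the only two with a number in this assay. Compound 1 gives 2.6 uM and compound 2 gives 4.4 uM; the two numbers lie within the usual scatter of each other, so neither can be set apart from the other on this evidence. Compound 3 was not determined and contributes nothing to the comparison. For the measured compounds named here, compound 2 also differs from compound 1 in more than one place, so no single-change step between measured compounds is available.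

The open question is compound 4 `CCCC1=C(OCCC(C)C)C(CCC)(CCC)C(=O)/C(=C(O)\C=C\c2ccccc2)C1=O`. Relative to compound 1, the change is isopropyl in place of hydrogen on a saturated chain carbon, two bonds along the chain from an oxygen on an unsaturated carbon. There is no measured step of this kind in the series, and the two numbers that exist do not separate. The working expectation is therefore a step from compound 1 to compound 4 of a 1.2-fold higher number from compound 1 to compound 4 (0.06 log units; within the scatter), which is not beyond the scatter in either direction. Compound 4 is accordingly estimated at 3 uM in this assay, with a range from 1 uM to 9 uM.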

Compound 4, concentration for half-maximal effect: 9.1 uM
Compound 4: middle estimate off by 3.0-fold (0.48 log units), on the low side; measured number outside the range, above it.
By their numbers in this assay, from the lowest: compounds 1 and 2 (each within the scatter of the next); then compound 4.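

Among the compounds shown here, this is the first single-change step. Going from ethoxy to isopentyloxy, which places isopropyl in place of hydrogen on a saturated chain carbon, two bonds along the chain from an oxygen on an unsaturated carbon, gives a 3.5-fold higher number from compound 1 to compound 4 (0.54 log units; beyond the scatter) in this assay. For the compounds shown here, the ethoxy position on the shared core is therefore not neutral to this change, although the higher number comes from only one pair of compounds. No supporting measurement bears on why the number moves with this change.

A single step cannot separate the effect of the added chain length from that of the branch, and a straight pentyloxy chain on the same oxygen would address that. On these data alone, whether an amine or a carboxylic acid on this chain would give a lower or higher number remains open.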